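Methyl to amino on the shared core

This account rests on a few compounds, and the source may have more. Where it says the series, first, only, none or still open, it means among the compounds named here.

Compound 1 `COc1cc(-c2cc(-c3ccc(C)cc3)nc(-c3ccccc3)n2)cc(OC)c1OC` gives in a functional assay on HT-29 cells (Homo sapiens) for inhibition, read by MTT assay, with a stated time of 48 h (a lower number here means a stronger inhibitor, a higher number a weaker inhibitor), only a limit, > 25000 nM. Compound 2 `COc1cc(-c2cc(-c3ccc(O)cc3)nc(-c3ccccc3)n2)cc(OC)c1OC` gives in this assay 11300 nM. The change to compound 3 `COc1cc(-c2cc(-c3ccc(N)cc3)nc(-c3ccccc3)n2)cc(OC)c1OC` is amino in place of methyl on an aromatic carbon. The measured step that bears on it is an at least 2.2-fold lower number from compound 1 to compound 2 (0.34 log units; beyond the scatter), where hydroxy replaces the same methyl that amino replaces here; compound 1 itself sits at the limit of > 25000 nM in this assay, at which 1 of the 2 values shown sits, so the true size of that step is open. A step of comparable size and direction is expected for compound 3, an at least 2.7-fold lower number from compound 1 to compound 3 (0.44 log units; beyond the scatter). Compound 3 is estimated at 9000 nM, with a range of 3000 nM to 25000 nM.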

Compound 3, half-maximal inhibitory concentration: > 25000 nM
Compound 3 was reported as a limit (the forecaster's own chance of this, stated with the estimate: 25%); at least 2.7-fold (0.44 log units) between middle value and limit.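

At this position, hydroxy and amino are not interchangeable on the shared core: the exchange gives an at least 2.2-fold higher number from compound 2 to compound 3 (0.34 log units; beyond the scatter). In this assay, compound 3 gives only a limit, > 25000 nM. Of the three groups, only hydroxy yields a value that is not a limit, and the step from compound 1 to compound 3 cannot be read: the limit of > 25000 nM in this assay, at which 2 of the 3 values shown sit.

Open, going by these compounds, is whether a methoxy group, a hydroxymethyl group or a carboxylic acid in the same place would give a measurable value, as hydroxy does. On these data alone, the size of the hydroxy step from methyl also remains open.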